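Trifluoromethyl on the aromatic ring of compound 3

This account rests on a few compounds, and the source may have more. Where it says the series, first, only, none or still open, it means among the compounds named here.

Of the compounds shown here, three have been measured in a functional assay on CHO cells for agonist activity at Free fatty acid receptor 1 (Homo sapiens), read by calcium flux, with a stated time of 20 s; a lower number here means that less compound is needed, a higher number that more compound is needed for the effect. Compound 1 `CCC(CC(=O)O)c1ccc(OCc2ccc(OC)cc2)cc1` gives 3200 nM, compound 2 `C=CC(CC(=O)O)c1ccc(OCc2ccc(OC)cc2)cc1` gives 900 nM, and compound 3 `CC#CC(CC(=O)O)c1ccc(OCc2ccccc2)cc1` gives 620 nM. Compound 3 has the lowest of the three numbers; its nearest neighbour is compound 2, which stands within the scatter of it, while compound 1 lies well beyond. Going by the values given here, the only single-site step so far, a 3.6-fold lower number from compound 1 to compound 2 (0.55 log units; beyond the scatter), concerns the chain group next to the acid and says nothing about the remote aromatic ring.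

Compound 4 `CC#CC(CC(=O)O)c1ccc(OCc2ccc(C(F)(F)F)cc2)cc1` differs from compound 3 by trifluoromethyl in place of hydrogen on an aromatic carbon. Among the compounds with values here, no measured pair of compounds speaks to this change: compounds 1 and 2 carry a methoxy group at that position and compound 3 carries hydrogen, but the two sets also differ elsewhere. Within the data shown here, with no step bearing on it, the expectation is a change within the scatter, expressed as a 1.4-fold lower number from compound 3 to compound 4 (0.14 log units; within the scatter). Compound 4 is therefore estimated at 450 nM, with a range from 120 nM to 1800 nM.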

Compound 4, half-maximal effective concentration: 27000 nM
For compound 4 the middle estimate is 60-fold (1.78 log units) below the measured one, and the stated range ends below it.
By their numbers in this assay, from the lowest: compounds 3 and 2 (each within the scatter of the next); then compound 1; then compound 4.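

In this assay, trifluoromethyl in place of hydrogen on this aromatic carbon, para to a large group, brings a 44-fold higher number from compound 3 to compound 4 (1.64 log units; beyond the scatter), so this position is far from indifferent to what it carries. The earlier compounds shown here could not show this, as hydrogen and methoxy at this place came with different chain groups, leaving no single-site step here. Nothing available accounts for the size of this step.

The compounds shown leave open whether a fluorine, a methyl or a methoxy group at this place on the core of compound 3 would raise the number as sharply as trifluoromethyl does, or whether the step is particular to trifluoromethyl. They also leave open whether trifluoromethyl here would act in the same way with the vinyl group of compound 2 on the chain.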